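Moving a Methoxy: From 2,5-dimethoxyphenyl to 3,5-dimethoxyphenyl

The source may hold more compounds than are shown below. What is called first, only, known or untested is meant among the compounds shown, and "the series" means these compounds.

Compound 1 `COc1ccc(OC)c(-c2cn(-c3ccc(O)c(C(=O)Nc4cccc(C(F)(F)F)c4)c3)nn2)c1` (> 100000 nM), a limit of the assay
Compound 2 `COc1ccccc1-c1cn(-c2ccc(O)c(C(=O)Nc3cccc(C(F)(F)F)c3)c2)nn1` (10500 nM)
Compound 3 `O=C(OCCCc1ccccc1)c1cc(-n2cc(-c3cc(O)ccc3O)nn2)ccc1O` (930 nM)

These three compounds were tested in a functional assay on CCRF-CEM cells (Homo sapiens) for inhibition, read by MTT assay, with a stated time of 2 days (on this read-out higher numbers stand for weaker inhibition of growth and lower numbers for stronger inhibition of growth), and compound 4 `COc1cc(OC)cc(-c2cn(-c3ccc(O)c(C(=O)Nc4cccc(C(F)(F)F)c4)c3)nn2)c1` awaits its result. Compound 1 gives only a limit and not a number (the limit of > 100000 nM in this assay, at which 1 of the 3 values shown sits). Compound 4 keeps the core of compound 1 and carries 3,5-dimethoxyphenyl in place of 2,5-dimethoxyphenyl on an aromatic carbon. Within the data shown here, the one measured step that bears on this change is an at least 9.5-fold lower number from compound 1 to compound 2 (0.97 log units; beyond the scatter) and comes with hydrogen in place of methoxy on an aromatic carbon. As far as these compounds go, it lies beyond the scatter, and its true size stays open on one side. Among the measured compounds shown here, compound 3 (930 nM) offers no single-place step to compound 1. Thus the evidence is one step, and it shows only that the substitution on this aromatic ring can shift the number. Compound 4 retains both methoxy groups, so a smaller shift than that of compound 2 (10500 nM) is expected. A second reading at the limit remains possible. The expected change is an at least 2.5-fold lower number from compound 1 to compound 4 (0.39 log units; beyond the scatter) in this assay and points to a lower number. The estimated value for compound 4 is 40000 nM (expected range 10000 nM to 100000 nM).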

Compound 4, concentration for 50% growth inhibition: 6410 nM
Estimate against measurement, compound 4: 6.2-fold (0.80 log units) above; the whole stated range lies above it.
By their numbers in this assay, from the lowest: compound 3; then compounds 4 and 2 (each within the scatter of the next). At a limit, above all of these: compound 1.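

In this assay, 3,5-dimethoxyphenyl in place of 2,5-dimethoxyphenyl gives an at least 15-fold lower number from compound 1 to compound 4 (1.19 log units; beyond the scatter), so with the same atoms joined differently, the arrangement of the two methoxy groups alone decides the result at this position. The true size of that step stays open on one side, because compound 1 gives only a limit of the assay and not a number: the limit of > 100000 nM in this assay, at which 1 of the 4 values shown sits.

The earlier step suggested that removing a methoxy group was what lowered the number, but the comparison with 2-methoxyphenyl gives a 1.6-fold lower number from compound 2 to compound 4 (0.21 log units; within the scatter), so compound 2 and compound 4 cannot be told apart in this assay even though compound 4 carries both methoxy groups.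

Compound 3 differs from the other compounds in more than one place, so its value cannot be tied to this ring alone. As far as these compounds go, it remains open whether a plain phenyl, or a hydroxyl or an amine in place of the methoxy groups, would stay level with compound 2 and compound 4 or would return to a limit like that of compound 1.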